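Pyrazolyl for pyridinyl at the aryl position of compound 3

A few compounds are considered here, and "the series" means these few. Any claim that something is new, unique, unknown or untested is made for them only; others in the source may bear on it.

Compound 1 `CCCn1ccc2cc(N3CCNCC3)cc(Cl)c2c1=O` carries a piperazin-1-yl group on the shared core. In a functional assay on CHO cells for agonist activity at metabotropic glutamate receptor 2 (Homo sapiens), read by GTPgammaS binding (a higher number here means that more compound is needed for the effect, a lower number that less compound is needed), compound 1 gives only a limit, > 10000 nM. Compound 2 `CCCn1ccc2cc(-c3ccncc3)cc(Cl)c2c1=O`, with pyridin-4-yl in that place, gives 1260 nM in this assay. Compound 3 `CCCn1ccc2cc(-c3cccnc3)cc(Cl)c2c1=O`, with pyridin-3-yl, gives 631 nM in this assay; this is the lowest of the two numbers, and compound 2 is its nearest neighbour within the scatter. The step of an at least 7.9-fold lower number from compound 1 to compound 2 (0.89 log units; beyond the scatter) and the step of an at least 15-fold lower number from compound 1 to compound 3 (1.19 log units; beyond the scatter) both show that replacing the piperazin-1-yl group by a six-membered aromatic ring brings a large drop, though the first value is a limit (the limit of > 10000 nM in this assay, at which 1 of the 3 values shown sits). The step of a 2.0-fold lower number from compound 2 to compound 3 (0.30 log units; within the scatter) shows that moving the nitrogen within the pyridinyl ring changes little.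

Compound 4 `CCCn1ccc2cc(-c3cn[nH]c3)cc(Cl)c2c1=O` differs from compound 3 in one place: 1H-pyrazol-4-yl in place of pyridin-3-yl on an aromatic carbon. Within the data shown here, the only measured step of the same kind, aromatic ring for aromatic ring, is a 2.0-fold lower number from compound 2 to compound 3 (0.30 log units; within the scatter), within the scatter; the large steps from compound 1 concern a different kind of change. In this assay compound 4 is therefore expected to stay near compound 3, the estimated step being a 1.3-fold higher number from compound 3 to compound 4 (0.10 log units; within the scatter), with no step beyond the scatter foreseen. The expected value for compound 4 is 800 nM, in the range 250 nM to 3000 nM.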

Compound 4, half-maximal effective concentration: 1580 nM
Beside the measured number, compound 4's estimate is 2.0-fold (0.30 log units) below it; the range from low to high includes it.
By their numbers in this assay, from the lowest: compounds 3, 2 and 4 (each within the scatter of the next, the first and the last beyond it). At a limit, above all of these: compound 1.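

In this assay, among these compounds, 1H-pyrazol-4-yl in place of pyridin-3-yl is the first exchange of one aromatic ring for another at this position to give a step beyond the scatter: a 2.5-fold higher number from compound 3 to compound 4 (0.40 log units; beyond the scatter). Set against pyridin-4-yl, the same ring gives a 1.3-fold higher number from compound 2 to compound 4 (0.10 log units; within the scatter), so the two pyridinyl groups, themselves within the scatter of each other, do not relate to the five-membered ring in the same way, and only pyridin-3-yl stands apart from it, by a modest step. The advantage of an aromatic ring over piperazin-1-yl also holds for a five-membered ring with a hydrogen-bond donor, as an at least 6.3-fold lower number from compound 1 to compound 4 (0.80 log units; beyond the scatter) shows, but that step rests on a limit for compound 1: the limit of > 10000 nM in this assay, at which 1 of the 4 values shown sits.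

Ring size, the count of ring nitrogens and the hydrogen-bond donor all change together in this exchange, and it remains open whether a 1-methylpyrazol-4-yl or a plain phenyl group at this position would separate them. Also open, as far as these compounds go, is how an amine or a carboxylic acid carried on the aromatic ring would read in this assay.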